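Methyl for methoxy at the limit of tolerance

This account rests on a few compounds, and the source may have more. Where it says the series, first, only, none or still open, it means among the compounds named here.

In an ADME assay on HEK293 cells (Homo sapiens) for cytotoxicity, read by resazurin assay, with a stated time of 48 h (a higher number here means that more compound is tolerated, a lower number that less compound is tolerated), compound 2 (`COc1ccccc1S(=O)(=O)Nc1ccc(-c2nc3ccccc3o2)cc1`) reads > 100000 nM as a limit of the assay, not a number. Compound 1 (`O=S(=O)(Nc1ccc(-c2nc3ccccc3o2)cc1)c1cccs1`) reads > 100000 nM as a limit too. Among the compounds with values here, the one measured step, a step that the two limits leave unreadable from compound 1 to compound 2 here, has no readable size, and the limit of > 100000 nM in this assay, at which 2 of the 2 values shown sit, sums up the evidence so far. Compound 3 (`Cc1ccccc1S(=O)(=O)Nc1ccc(-c2nc3ccccc3o2)cc1`) keeps the rest of compound 2 and differs by methyl in place of methoxy on an aromatic carbon in one place, with methyl in place of methoxy on an aromatic carbon. Within the data shown here, no measured step covers this change directly. Among the measured compounds shown here, with a step that the two limits leave unreadable from compound 1 to compound 2 as the only guide, no shift beyond the scatter is expected in this assay and a limit reading is likely. The estimated step is a number no higher from compound 2 to compound 3 (the limit leaves the size open) on this reasoning. For compound 3 the expected value is 100000 nM (estimated range 50000 nM to 200000 nM).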

Compound 3, half-maximal cytotoxic concentration: > 100000 nM
Compound 3 gave a limit, no number (the forecaster's own chance of this, stated with the estimate: 85%); the middle value lies on the limit itself.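

Compound 3 is also a limit of the assay and not a number, so the steps among compound 1, compound 2 and compound 3 cannot be read in this assay: the limit of > 100000 nM in this assay, at which 3 of the 3 values shown sit.

The compounds shown leave open where each true value lies, and whether methyl in place of methoxy shifts it at all.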